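This account rests on a few compounds, and the source may have more. Where it says the series, first, only, none or still open, it means among the compounds named here.

Measured compounds:

Compound 1, `Cc1ccc(-n2cc(C(=O)Nc3cc(F)cc(F)c3)c(=O)c3ccc(N(C)C)nc32)cc1OCCCCCCC[N+]12CCN(CC1)CC2`, gives 9.71% in an assay on LX2 cells for inhibition of COL1A1 promoter (Homo sapiens), read by a luciferase reporter, with a stated time of 24 h, tested at 50 uM; a higher number here means a stronger effect of the compound at the concentration tested, a lower number a weaker effect.
Compound 2, `Cc1ccc(-n2cc(C(=O)Nc3cc(F)cc(F)c3)c(=O)c3ccc(N(C)C)nc32)cc1OCCCCCCC[N+]1(C)CCCC1`, gives 55.9% in this assay.
Compound 3, `Cc1ccc(-n2cc(C(=O)Nc3cc(F)cc(F)c3)c(=O)c3ccc(N(C)C)nc32)cc1OCCCCCCC[N+]1(C)CCN(C)CC1`, gives 25% in this assay.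

Compound 3 stands second highest of the three numbers; its nearest neighbour is compound 1, which sits lower by a step beyond the usual scatter, and its furthest is compound 2, which sits higher by a step beyond the scatter. All three share one core and differ only in the charged ring group at the end of the chain.

Compound 4, `CC[N+]1(CCCCCCCOc2cc(-n3cc(C(=O)Nc4cc(F)cc(F)c4)c(=O)c4ccc(N(C)C)nc43)ccc2C)CCCC1`, has not yet been measured. Its change from compound 3 is a group of 7 heavy atoms (6 carbon, 1 nitrogen; one five-membered non-aromatic ring with 1 hetero atom) in place of a group of 8 heavy atoms (6 carbon, 2 nitrogen; one six-membered non-aromatic ring with 2 hetero atoms), on a saturated chain carbon, seven bonds along the chain from an oxygen on an aromatic ring

The measured step that bears most directly on this is the one in the opposite direction, a number 30.9 percentage points lower from compound 2 to compound 3 (beyond the scatter), where the six-membered ring with two hetero atoms replaced a five-membered ring with one hetero atom and the number fell by a large amount. Compound 4 carries a five-membered ring with one hetero atom much like compound 2, differing only in the size of the small alkyl group on the charged nitrogen. The expected step is therefore a large rise, a number 25 percentage points higher from compound 3 to compound 4 (beyond the scatter), bringing compound 4 close to compound 2. Compound 4 is estimated at 50%, with a likely range from 30% to 68%.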

Compound 4, a percentage reported as inhibition, at one concentration (the size of the read-out at that concentration, not a potency): 81.4%
Estimate against measurement, compound 4: 31.4 percentage points below; the measured number lies above the stated range.
By their numbers in this assay, from the lowest: compound 1; then compound 3; then compound 2; then compound 4.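

Among these compounds, at this position, the end of the chain, the earlier compounds showed only what happens when a whole ring group changes, whereas compound 4 shows that a single added carbon also counts in this assay: methyl in place of hydrogen on a saturated chain carbon bound to an amine nitrogen in a ring gives a number 25.5 percentage points higher from compound 2 to compound 4 (beyond the scatter), a step beyond the usual scatter. The full change of ring group gives a number 56.4 percentage points higher from compound 3 to compound 4 (beyond the scatter), and measured against the group with two six-membered rings it gives a number 71.7 percentage points higher from compound 1 to compound 4 (beyond the scatter), which makes compound 4 the highest of the four. In these four compounds, both of those with a five-membered ring sit above both of those with six-membered rings, and none goes against this order, although four compounds are too few to show a general rule.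

Nothing shown here explains why the five-membered ring and the added carbon raise the number. From the compounds shown here alone, it remains open whether a propyl group in that same place would raise the number further or lower it, and whether a piperidine ring carrying an ethyl group would reach the level of compound 4.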